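Halogen swap on the aromatic ring: bromo to chloro

The source may hold more compounds than are shown below. What is called first, only, known or untested is meant among the compounds shown, and "the series" means these compounds.

Compound 1 `COC(=O)[C@@]1(C)CC[C@@H]2C3=C1CC[C@@H](C)[C@]3(C)C[C@@H]1c3cccc(C)c3N[C@H]21` carries a methyl on the aromatic carbon; in a functional assay on T47D cells (Homo sapiens) for inhibition, read by sulforhodamine B assay, with a stated time of 48 h (on this read-out higher numbers stand for weaker inhibition of growth and lower numbers for stronger inhibition of growth), compound 1 gives 29000 nM. Within the data shown here, compound 2 `COC(=O)[C@@]1(C)CC[C@@H]2C3=C1CC[C@@H](C)[C@]3(C)C[C@@H]1c3cccc(Br)c3N[C@H]21` carries bromo at that place; in this assay compound 2 gives 37000 nM, which stands within the scatter of compound 1 and is the only other number measured so far. The step of a 1.3-fold higher number from compound 1 to compound 2 (0.11 log units; within the scatter) did not leave the scatter, so methyl and bromo at this place are not distinguished by this assay.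

Compound 3 `COC(=O)[C@@]1(C)CC[C@@H]2C3=C1CC[C@@H](C)[C@]3(C)C[C@@H]1c3cccc(Cl)c3N[C@H]21` differs from compound 2 by chloro in place of bromo on an aromatic carbon. Among the measured compounds shown here, no measured step exchanges one halogen for another; the only step that bears on this place was a 1.3-fold higher number from compound 1 to compound 2 (0.11 log units; within the scatter), and it was negligible. A step of similar size, or none beyond the scatter, is expected here. The estimated step from compound 2 to compound 3 in this assay is a 1.1-fold lower number from compound 2 to compound 3 (0.05 log units; within the scatter). Compound 3 is therefore expected to give about 33000 nM in this assay, with a range from 15000 nM to 70000 nM.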

Compound 3, concentration for 50% growth inhibition: 50000 nM
Estimate against measurement, compound 3: 1.5-fold (0.18 log units) below; the measured number falls inside the stated range.
By their numbers in this assay, from the lowest: compounds 1, 2 and 3 (each within the scatter of the next).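

Chloro adds a third group on this aromatic carbon in this assay, and a 1.4-fold higher number from compound 2 to compound 3 (0.13 log units; within the scatter) adds a halogen exchange to the earlier comparison of methyl with bromo. Among these compounds, the other new comparison, a 1.7-fold higher number from compound 1 to compound 3 (0.24 log units; within the scatter), also stays within the scatter, so no pair among methyl, bromo and chloro is separated at this place. The assay therefore gives no ranking of these three groups, and a change between the two halogens is no more visible here than a change from methyl to either one. Nothing available bears on why the three groups read alike. 

As far as these compounds go, whether this place can respond at all remains open, as a hydrogen, an amine, a methoxy group or a carboxylic acid on this carbon might read differently from these three. From the compounds shown here alone, whether any change elsewhere on the shared core would move the number also remains open.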